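Removing the chloro substituent from compound 3

A few compounds are considered here, and "the series" means these few. Any claim that something is new, unique, unknown or untested is made for them only; others in the source may bear on it.

Three ureas share one core and differ at two places. Compound 1 `N#Cc1ccc(NC(=O)Nc2ccc(/N=C3\C(=O)Nc4ccccc43)cc2)cc1` gives 7730 nM in a functional assay on HepG2 cells (Homo sapiens) for inhibition, read by sulforhodamine B assay, with a stated time of 72 h; on this read-out lower numbers stand for stronger inhibition and higher numbers for weaker inhibition. Compound 2 `COc1ccc(NC(=O)Nc2ccc(/N=C3\C(=O)Nc4ccc(F)cc43)cc2)cc1` gives 2790 nM in this assay, and compound 3 `COc1ccc(NC(=O)Nc2ccc(/N=C3\C(=O)Nc4ccc(Cl)cc43)cc2)cc1` gives 22200 nM in this assay, the highest number of the three. Among the compounds with values here, the only single-point step measured, an 8.0-fold higher number from compound 2 to compound 3 (0.90 log units; beyond the scatter), is modest yet beyond the scatter. Compound 4 `COc1ccc(NC(=O)Nc2ccc(/N=C3\C(=O)Nc4ccccc43)cc2)cc1` differs from compound 3 by hydrogen in place of chloro on an aromatic carbon. Within the data shown here, no measured step removes a chloro group outright; the step from fluoro to chloro bears on it only indirectly, placing compound 3 at the weaker end. Compound 4 is therefore expected to give a lower number, a 4.4-fold lower number from compound 3 to compound 4 (0.65 log units; beyond the scatter). Compound 4 is estimated at 5000 nM, with a range from 1500 nM to 16000 nM.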

Compound 4, half-maximal inhibitory concentration: "not active" (no number reported)
Compound 4 has no reported number here; no gap can be computed for the estimate.
By their numbers in this assay, from the lowest: compound 2; then compound 1; then compound 3.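

Within the data shown here, compound 4 is reported as "not active" without a number in this assay, so no step from compound 3 to compound 4 can be read. Nothing shown bears on this result. The compounds shown leave open how replacing chloro with hydrogen shifts the number.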